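Replacing the sulfur hydrogen of compound 3 with an acetamidoethyl chain

This account rests on a few compounds, and the source may have more. Where it says the series, first, only, none or still open, it means among the compounds named here.

Measured compounds:
compound 1, `CC(C)c1n[nH]c2c(NCc3ccc(-c4ccccn4)cc3)nc(SCC(O)CN)nc12`, 55 nM
compound 2, `CNCCSc1nc(NCc2ccc(-c3ccccn3)cc2)c2[nH]nc(C(C)C)c2n1`, 56 nM
compound 3, `CC(C)c1n[nH]c2c(NCc3ccc(-c4ccccn4)cc3)nc(S)nc12`, 2760 nM

In a functional assay on HT cells (Homo sapiens) for antiproliferative activity, read by fluorescence, with a stated time of 72 h (a higher number here means a weaker inhibitor of growth, a lower number a stronger inhibitor of growth), compound 1 gives 55 nM and compound 2 gives 56 nM; the two differ by a 1.0-fold higher number from compound 1 to compound 2 (0.01 log units; within the scatter). Compound 3 gives 2760 nM, the highest number of the three, beyond the scatter from both others.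

Compound 4 is `CC(=O)NCCSc1nc(NCc2ccc(-c3ccccn3)cc2)c2[nH]nc(C(C)C)c2n1`. It differs from compound 3 by 2-acetamidoethyl in place of hydrogen on a sulfur. The two steps that bear on this are the reverse of a 50-fold higher number from compound 1 to compound 3 (1.70 log units; beyond the scatter) and of a 49-fold higher number from compound 2 to compound 3 (1.69 log units; beyond the scatter): in both, removing the chain on the sulfur raised the number strongly, so putting a chain back is expected to lower it. Those two chains each carry a basic nitrogen, whereas the chain entering in compound 4 carries an acetamido group, a difference the data do not test. The expectation is therefore for a step of a 9.2-fold lower number from compound 3 to compound 4 (0.96 log units; beyond the scatter), downward but more cautious than the full reversal. Compound 4 is expected at about 300 nM, within 80 nM to 1200 nM.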

Compound 4, concentration for 50% growth inhibition: 71 nM
Beside the measured number, compound 4's estimate is 4.2-fold (0.63 log units) above it, and the stated range ends above it.
By their numbers in this assay, from the lowest: compounds 1, 2 and 4 (each within the scatter of the next); then compound 3.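

In this assay, 2-acetamidoethyl in place of hydrogen on the sulfur gives a 39-fold lower number from compound 3 to compound 4 (1.59 log units; beyond the scatter), so a large step at this position also occurs with a chain whose nitrogen carries an acetyl group, not only with the amine chains of compound 1 and compound 2. Acetyl in place of methyl on the amine nitrogen gives a 1.3-fold higher number from compound 2 to compound 4 (0.10 log units; within the scatter), and the comparison with the hydroxy amine chain gives a 1.3-fold higher number from compound 1 to compound 4 (0.11 log units; within the scatter), both within the scatter, so a free amine on the chain is not needed for a number in this range among these compounds. Nothing measured here explains why these three chains read alike.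

On these data alone, whether the chain needs a nitrogen at all remains open. So does how a plain ethyl chain, a carboxylic acid or a longer chain on the sulfur would read in this assay.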